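This account rests on a few compounds, and the source may have more. Where it says the series, first, only, none or still open, it means among the compounds named here.

Compound 1 `COc1cc(OC)c2sc(-c3ccc(N/C=C\C(=O)c4ccc(OC)c(O)c4)c(C)c3)nc2c1`: 16100 nM
Compound 2 `COc1ccc(C(=O)/C=C\Nc2ccc(-c3nc4cc(OC)c(OC)c(OC)c4s3)cc2C)cc1O`: 11400 nM
Compound 3 `COc1ccc(C(=O)/C=C\Nc2ccc(-c3nc4cc(OC)c(OC)c(OC)c4s3)cc2)cc1O`: 14100 nM

All three compounds were measured in a functional assay on HeLa cells (Homo sapiens) for antiproliferative activity, read by sulforhodamine B assay, with a stated time of 48 h; a higher number here means a weaker inhibitor, a lower number a stronger inhibitor. Compound 2, at 11400 nM, lies within the scatter of both compound 1 and compound 3, so the numbers set no order among the three.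

Compound 4 `COc1cc(C(=O)/C=C\Nc2ccc(-c3nc4cc(OC)c(OC)c(OC)c4s3)cc2C)cc(OC)c1OC` has not yet been measured. It differs from compound 2 in one place: 3,4,5-trimethoxyphenyl in place of 3-hydroxy-4-methoxyphenyl on a carbonyl carbon. In short, 3,4,5-trimethoxyphenyl stands in place of 3-hydroxy-4-methoxyphenyl on a carbonyl carbon.

Two measured steps lie nearby, but neither touches this group, which all three measured compounds carry. The first is a 1.4-fold lower number from compound 1 to compound 2 (0.15 log units; within the scatter), with methoxy in place of hydrogen on an aromatic carbon. The second is a 1.2-fold higher number from compound 2 to compound 3 (0.09 log units; within the scatter), with hydrogen in place of methyl on an aromatic carbon. Within the data shown here, both lie within the scatter, and they give only indirect guidance, since no measurement yet tests this exchange.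

No step beyond the scatter is therefore expected in this assay, and the data favour no direction, though the uncertainty is wide. The expected step is a 1.1-fold higher number from compound 2 to compound 4 (0.06 log units; within the scatter). The estimated value for compound 4 is 13000 nM, with an expected range from 5000 nM to 35000 nM.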

Compound 4, half-maximal inhibitory concentration: 11100 nM
Compound 4: the middle estimate sits 1.2-fold (0.07 log units) above what was measured; measured number inside the range.
By their numbers in this assay, from the lowest: compounds 4, 2, 3 and 1 (each within the scatter of the next).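

Compound 4 is the only compound shown in which the aryl group on the carbonyl carbon differs, and in this assay the exchange of 3-hydroxy-4-methoxyphenyl for 3,4,5-trimethoxyphenyl gives a 1.0-fold lower number from compound 2 to compound 4 (0.01 log units; within the scatter), which lies within the scatter. The entering group has 0 hydrogen-bond donors against 1 in the group that leaves, and 12 heavy atoms against 9, yet this pair of compounds shows no measurable difference in this assay, so at this position the hydroxy group can be exchanged for a methoxy group without a step beyond the scatter. No measured evidence is available that bears on why the two groups read alike.

As far as these compounds go, this single pair tests the position only on the shared core of compound 2 and compound 4, so it remains open whether the same exchange would behave alike with the core of compound 1 or compound 3. From the compounds shown here alone, it also remains open whether a more different aryl group on the carbonyl carbon, such as a phenyl ring carrying a dimethylamino group or a carboxylic acid, would move the number beyond the scatter.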